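From 2-methylpiperidin-1-yl to ethyl((pyridin-4-yl)methyl)amino

This account rests on a few compounds, and the source may have more. Where it says the series, first, only, none or still open, it means among the compounds named here.

Of the compounds shown here, three built on a shared core have been measured so far in a functional assay on MGC-803 cells (Homo sapiens) for antiproliferative activity, read by CCK-8 assay, with a stated time of 72 h (on this read-out higher numbers stand for weaker inhibition and lower numbers for stronger inhibition), and give closely grouped numbers. Compound 1 `Nc1ccccc1NC(=O)c1ccc(CSC(=S)N2CCc3ccccc32)cc1` comes in at 2300 nM and compound 2 `Nc1ccccc1NC(=O)c1ccc(CSC(=S)N2CCc3cc(Cl)ccc32)cc1` at 1890 nM while compound 3 `CC1CCCCN1C(=S)SCc1ccc(C(=O)Nc2ccccc2N)cc1` stands at 1610 nM on the same scale. Compound 3 thus sits level with the other two, with each gap inside the usual scatter of repeat measurements.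

The next change leads to compound 4 `CCN(Cc1ccncc1)C(=S)SCc1ccc(C(=O)Nc2ccccc2N)cc1` and replaces the group on a thiocarbonyl carbon: ethyl((pyridin-4-yl)methyl)amino in place of 2-methylpiperidin-1-yl on a thiocarbonyl carbon in short, ethyl((pyridin-4-yl)methyl)amino in place of 2-methylpiperidin-1-yl.

Two measured steps changed that same group: a 1.4-fold lower number from compound 1 to compound 3 (0.15 log units; within the scatter) and a 1.2-fold lower number from compound 2 to compound 3 (0.07 log units; within the scatter) are both small and within the scatter. A third step, a 1.2-fold lower number from compound 1 to compound 2 (0.09 log units; within the scatter) with chloro in place of hydrogen on an aromatic carbon, is equally within the scatter. For the measured compounds named here, none of them brought in ethyl((pyridin-4-yl)methyl)amino, and the data hold no direct precedent for it. Across these three compounds the steps stay small, and no step beyond the scatter is expected in this assay in either direction. The estimate amounts to a 1.1-fold higher number from compound 3 to compound 4 (0.05 log units; within the scatter) as an expected step. For compound 4 the estimated value is 1800 nM with an expected range from 800 nM to 4000 nM in repeat measurements.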

Compound 4, half-maximal inhibitory concentration: 1370 nM
Beside the measured number, compound 4's estimate is 1.3-fold (0.12 log units) above it; low and high end bracket the measured number.
By their numbers in this assay, from the lowest: compounds 4, 3, 2 and 1 (each within the scatter of the next).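

In this assay, the step to the open-chain ethyl((pyridin-4-yl)methyl)amino group is a 1.2-fold lower number from compound 3 to compound 4 (0.07 log units; within the scatter), so a group with an aromatic ring and a hydrogen-bond acceptor on the thiocarbonyl carbon gives a number level with that of the non-aromatic 2-methylpiperidin-1-yl ring. The comparisons with the two other groups at this position tell the same story: a 1.4-fold lower number from compound 2 to compound 4 (0.14 log units; within the scatter) and a 1.7-fold lower number from compound 1 to compound 4 (0.23 log units; within the scatter). All four groups on the thiocarbonyl carbon, whether non-aromatic ring, fused ring system or open chain with a pyridine ring, therefore give numbers within the scatter of one another, though no information is at hand on why this position responds so little.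

The compounds shown leave open what a plain phenyl ring in place of the pyridin-4-yl ring would do, a swap that would test the ring nitrogen on its own. They also leave open whether a morpholine ring or a chain ending in a carboxylic acid on the thiocarbonyl carbon would give a step beyond the scatter.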